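Smaller ester on the shared core: compound 3 to compound 4

The source may report more compounds than this note shows. Statements on the series, on what has been measured and on what is new or still open speak of the compounds shown alone.

This account concerns a small set of dihydropyridine-type compounds tested in a functional assay (cardiac atrium) for agonist activity, with Cavia porcellus as the target; a lower number here means that less compound is needed, a higher number that more compound is needed for the effect. Compound 3 `CC1=NC(C)=C([N+](=O)[O-])C(c2cccnc2)/C1=C(\O)OC1CCCCC1` gives 2760 nM in this assay, the lowest of the three numbers. Compound 1 `CCO/C(O)=C1\C(C)=NC(C)=C([N+](=O)[O-])C1c1ccncc1` gives 6460 nM in this assay, a higher number than compound 3 and beyond the scatter. Compound 2 `CC1=NC(C)=C([N+](=O)[O-])C(c2ccccn2)/C1=C(\O)OC1CCCC1` gives 19800 nM in this assay, the highest number of the three and furthest from compound 3. Going by the values given here, compounds 1 and 2 differ from compound 3 in more than one place, so no single step between them is counted here.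

Compound 4 `CC1=NC(C)=C([N+](=O)[O-])C(c2cccnc2)/C1=C(\O)OC(C)C` differs from compound 3 in one place: isopropyl in place of cyclohexyl on an oxygen on an unsaturated carbon. Among the compounds with values here, nothing among the measured compounds isolates this change, so the expected size of the step rests on the structural change alone. The step from compound 3 to compound 4 is expected to be a modest rise in the number, a 1.8-fold higher number from compound 3 to compound 4 (0.26 log units; within the scatter), probably not far beyond the scatter. Compound 4 is therefore estimated at 5000 nM in this assay, within a range from 1500 nM to 16000 nM.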

Compound 4, half-maximal effective concentration: 28500 nM
For compound 4 the middle estimate is 5.7-fold (0.76 log units) below the measured one, outside the stated range (above it).
By their numbers in this assay, from the lowest: compound 3; then compound 1; then compounds 2 and 4 (each within the scatter of the next).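

In this assay, isopropyl in place of cyclohexyl on an oxygen on an unsaturated carbon brings a 10-fold higher number from compound 3 to compound 4 (1.01 log units; beyond the scatter), a large step well beyond the scatter. Going by these compounds alone, this is the first pair in the set that differs in one place only, and it shows that the number responds strongly to the group on this oxygen, with the rest of the shared core unchanged. Nothing at hand gives a measured basis for explaining the size of this step.

The compounds shown leave open whether a straight butyl chain or a benzyl group on this oxygen would give a number nearer that of compound 3 or that of compound 4. As far as these compounds go, it also remains open whether the same change would bring a step of this size on the cores of compound 1 and compound 2.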